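Cytotoxicity in MT4 cells: trimming a pyrrolidine to methyl

This account rests on a few compounds, and the source may have more. Where it says the series, first, only, none or still open, it means among the compounds named here.

Measured so far:
- compound 1, `Oc1ccc(-c2nc3cc(C(F)(F)F)ccc3[nH]2)cc1`: 17000 nM
- compound 2, `Cn1c(-c2ccc(NC(=O)CN3CCCC3)cc2)nc2cc(C(F)(F)F)ccc21`: 16000 nM
- compound 3, `CC(=O)Nc1ccc(-c2nc3ccccc3[nH]2)cc1`: 100000 nM

All three were tested in an ADME assay on MT4 cells (Homo sapiens) for cytotoxicity, read by MTT assay, with a stated time of 96 h; on this read-out lower numbers stand for higher toxicity in this test and higher numbers for lower toxicity in this test. Compound 2 gives the lowest of the three numbers, but compound 1 sits within the usual scatter of it, so the two cannot be told apart. Among the compounds with values here, compound 3 stands well beyond the scatter, at the high end, and is the only other compound here that carries an amide on the pendant ring.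

Compound 4, `CCC(=O)Nc1ccc(-c2nc3cc(C(F)(F)F)ccc3n2C)cc1`, has not yet been measured. It differs from compound 2 by methyl in place of pyrrolidin-1-yl on a saturated chain carbon bound to a carbonyl carbon; the pyrrolidin-1-yl leaves and a methyl enters. Within the data shown here, no pair of measured compounds shows this change, so the direction of the step is uncertain. Compound 3, the nearest measured amide, gives 100000 nM in this assay, which points towards a somewhat higher number for compound 4. The step from compound 2 to compound 4 is expected to be modest, a 1.9-fold higher number from compound 2 to compound 4 (0.27 log units; within the scatter), towards lower toxicity. Compound 4 is thus estimated at 30000 nM, within a range of 12000 nM to 90000 nM.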

Compound 4, half-maximal cytotoxic concentration: 8000 nM
For compound 4 the middle estimate is 3.8-fold (0.57 log units) above the measured one; measured number below the stated range.
By their numbers in this assay, from the lowest: compounds 4, 2 and 1 (each within the scatter of the next, the first and the last beyond it); then compound 3.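

In this assay, the step from the pyrrolidin-1-yl group to methyl on the saturated chain carbon bound to a carbonyl carbon gives a 2.0-fold lower number from compound 2 to compound 4 (0.30 log units; within the scatter). Within the data shown here, this is the first direct reading at this position, and it shows that removing the five-membered non-aromatic ring with its nitrogen, leaving a propanoylamino group, produces no difference that can be told from the usual scatter. Nothing available here explains this result or shows what the two groups do in the cells.

As far as these compounds go, with a single step at this position, it remains open whether the ring or its nitrogen has any bearing on the number. A dimethylamino group or a cyclopentyl ring on the same carbon, or a longer chain in place of the methyl, would help to separate these possibilities.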